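A few compounds are considered here, and "the series" means these few. Any claim that something is new, unique, unknown or untested is made for them only; others in the source may bear on it.

Three compounds have numbers in an assay on HEK293 cells for agonist activity at transient receptor potential cation channel subfamily M member 8 (Homo sapiens), read by fluorescence and calcium flux, with a stated time of 15 min; on this read-out higher numbers stand for an effect only at larger amounts of compound and lower numbers for an effect already at smaller amounts:

compound 1, `CCN(Cc1cccs1)C(=O)C(C)Oc1ccc(C)cc1`: 889 nM
compound 2, `CCN(Cc1cccn1C)C(=O)COc1ccc(C)cc1`: 21300 nM
compound 3, `C=CCN(Cc1cccs1)C(=O)COc1ccc(C)cc1`: 20 nM

Compound 3 stands lowest of the three numbers. Its nearest neighbour is compound 1, whose number is higher by a gap beyond the usual scatter, and compound 2 lies furthest, higher still by a gap well beyond the scatter. No two of the measured compounds differ in only one place, so no single structural change has been quantified within this set.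

Compound 4, `Cc1ccc(OCC(=O)N(Cc2cccs2)c2ccccc2)cc1`, remains to be measured. It differs from compound 3 by phenyl in place of allyl on an amide-type nitrogen. Within the data shown here, nothing among the measured compounds shows what this particular change does, so the expectation leans on the spread already seen: every departure from compound 3 so far has given a higher number. The step of a 13-fold higher number from compound 3 to compound 4 (1.10 log units; beyond the scatter) is therefore expected to be upward and beyond the scatter, though with wide uncertainty. For compound 4 the estimate is 250 nM. The expected range for compound 4 runs from 30 nM to 3000 nM.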

Compound 4, half-maximal effective concentration: 23 nM
Compound 4: middle estimate off by 11-fold (1.04 log units), on the high side; the measured number lies below the stated range.
By their numbers in this assay, from the lowest: compounds 3 and 4 (each within the scatter of the next); then compound 1; then compound 2.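

In this assay, phenyl in place of allyl on the amide-type nitrogen gives a 1.2-fold higher number from compound 3 to compound 4 (0.06 log units; within the scatter), the first single change read in this series. At this position, then, a low number does not depend on the double bond of allyl: a group with 6 heavy atoms and one six-membered aromatic ring reads level with one of 3 heavy atoms and no ring. No measured evidence bears on why the two groups read alike.

Still open, as far as these compounds go, is whether a longer chain, a benzyl group or a chain ending in an amine on this nitrogen would also hold the number level. From the compounds shown here alone, the effect of ethyl on this nitrogen also stays open, as compound 1 differs from compound 3 in more than one place.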